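This account rests on a few compounds, and the source may have more. Where it says the series, first, only, none or still open, it means among the compounds named here.

For the measured compounds named here, in an ADME assay (liver) for metabolic stability, with Liver microsome (Rattus norvegicus) as the target, using microsomes and NADPH, with a stated time of 30 min, tested at 1 uM (on this read-out lower numbers stand for slow clearance and higher numbers for fast clearance), three compounds sharing one core have numbers so far: compound 1 `COCC#Cc1cc(C(O)(C(F)(F)F)C(F)(F)F)cnc1N1CCN(S(=O)(=O)c2ccc(N)nc2)CC1` gives 399 mL.min-1.g-1, compound 2 `CCn1cc(-c2cc(C(O)(C(F)(F)F)C(F)(F)F)cnc2N2CCN(S(=O)(=O)c3ccc(N)nc3)CC2)cn1` gives 194 mL.min-1.g-1, and compound 3 `Nc1ccc(S(=O)(=O)N2CCN(c3ncc(C(O)(C(F)(F)F)C(F)(F)F)cc3-c3ccccc3O)CC2)cn1` gives 125 mL.min-1.g-1. Compound 3 stands clearly apart from one of them, with a 3.2-fold lower number from compound 1 to compound 3 (0.50 log units; beyond the scatter), but not from the other, with a 1.6-fold lower number from compound 2 to compound 3 (0.19 log units; within the scatter). The remaining step is a 2.1-fold lower number from compound 1 to compound 2 (0.31 log units; beyond the scatter). Compound 4 `Nc1ccc(S(=O)(=O)N2CCN(c3ncc(C(O)(C(F)(F)F)C(F)(F)F)cc3-c3ccncc3)CC2)cn1` carries pyridin-4-yl in place of 2-hydroxyphenyl on an aromatic carbon. Going by the values given here, the closest precedent is the exchange of one aromatic group for another, a 1.6-fold lower number from compound 2 to compound 3 (0.19 log units; within the scatter), so no change beyond the scatter is expected. The estimated step is a 1.3-fold higher number from compound 3 to compound 4 (0.11 log units; within the scatter). For compound 4 the expected value is 160 mL.min-1.g-1, with an estimated range of 70 mL.min-1.g-1 to 350 mL.min-1.g-1.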

Compound 4, intrinsic clearance in microsomes: 31 mL.min-1.g-1
Estimate against measurement, compound 4: 5.2-fold (0.71 log units) above, and the stated range ends above it.
By their numbers in this assay, from the lowest: compound 4; then compounds 3 and 2 (each within the scatter of the next); then compound 1.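

In this assay, the earlier exchange of one aromatic group for another at this carbon stayed within the scatter, so the identity of the aromatic ring seemed to matter little, but pyridin-4-yl changes that picture (a 4.0-fold lower number from compound 3 to compound 4 (0.61 log units; beyond the scatter)). The gap also holds against the other two groups (a 6.3-fold lower number from compound 2 to compound 4 (0.80 log units; beyond the scatter)) and (a 13-fold lower number from compound 1 to compound 4 (1.11 log units; beyond the scatter)), leaving compound 4 with the lowest number of the four. Nothing shown here explains the drop. The compounds shown do not separate the gain of the ring nitrogen from the loss of the hydroxy group. Unsubstituted phenyl or pyridin-3-yl at this carbon would address that.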